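Working notes: cytotoxicity tolerance across three related compounds

The compounds below may be only part of what the source reports. "The series", "measured", "known", "first", "only" and "open" are said of these compounds alone.

Compound 1 `CN(C)CCCN(/N=N/c1cc(F)ccc1F)c1cccc(C(F)(F)F)c1`: 30000 nM
Compound 2 `Fc1ccc(F)c(/N=N/Nc2ccccc2)c1`: 80000 nM

Two compounds are measured in an ADME assay on Vero cells (Chlorocebus sabaeus) for cytotoxicity, read by crystal violet staining; a higher number here means that more compound is tolerated, a lower number that less compound is tolerated. Compound 2 gives 80000 nM, the highest of the two numbers; compound 1 gives 30000 nM, a lower number, and this gap lies beyond the usual scatter. Compound 3 `Fc1ccc(F)c(/N=N/Nc2cccc(C(F)(F)F)c2)c1` is not yet measured in this assay. It differs from compound 2 by trifluoromethyl in place of hydrogen on an aromatic carbon. Going by the values given here, no measured pair shows this change on its own, so the size of the step is open; a modest decrease, or no step beyond the scatter, is expected, with an estimated step of a 1.6-fold lower number from compound 2 to compound 3 (0.20 log units; within the scatter). For compound 3 the estimate is 50000 nM, with a range from 20000 nM to 120000 nM.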

Compound 3, half-maximal cytotoxic concentration: 80000 nM
Compound 3: the middle estimate sits 1.6-fold (0.20 log units) below what was measured; the range from low to high includes it.
By their numbers in this assay, from the lowest: compound 1; then compounds 2 and 3 (each within the scatter of the next).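

In this assay, going by these compounds alone, trifluoromethyl on this aromatic carbon, meta to a large group, gives no change at the digits printed from compound 2 to compound 3 (within the scatter) as the only change, so this position takes the group without a step beyond the scatter. With trifluoromethyl present on both sides, hydrogen in place of 3-(dimethylamino)propyl on the nitrogen gives a 2.7-fold higher number from compound 1 to compound 3 (0.43 log units; beyond the scatter) as a single-place change, which the earlier pair could not isolate. Nothing available explains either step. From the compounds shown here alone, whether a carboxylic acid or an amine on this aromatic carbon would behave alike remains open, as does the effect of a shorter amine chain on the nitrogen.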